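A few compounds are considered here, and "the series" means these few. Any claim that something is new, unique, unknown or untested is made for them only; others in the source may bear on it.

Compound 1 `S=C(N/N=C/c1cccs1)Nc1ccc(Cl)cc1`: 14700 nM
Compound 2 `S=C(N/N=C/c1cccs1)Nc1ccccc1`: > 100000 nM

These two compounds were tested in an ADME assay on HaCaT cells (Homo sapiens) for inhibition, read by sulforhodamine B assay, with a stated time of 48 h; a lower number here means a stronger inhibitor of growth, a higher number a weaker inhibitor of growth. Compound 2 gives > 100000 nM, which is a limit of the assay and not a number, so its place on the scale is known only as that limit. Compound 3 `Cc1ccc(NC(=S)N/N=C/c2cccs2)cc1` differs from compound 2 by methyl in place of hydrogen on an aromatic carbon. Among the measured compounds shown here, one measured step bears on this change, the exchange of chloro for hydrogen on an aromatic carbon: an at least 6.8-fold higher number from compound 1 to compound 2 (0.83 log units; beyond the scatter). Read in reverse, this step shows that a group in place of that hydrogen can come with a lower number. Methyl is a different group, so a step in the same direction is expected, though with much uncertainty in its size. The expected change is an at least 2.5-fold lower number from compound 2 to compound 3 (0.39 log units; beyond the scatter). For compound 3 the estimate is 40000 nM, with an expected range of 13000 nM to 100000 nM.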

Compound 3, concentration for 50% growth inhibition: 17600 nM
Beside the measured number, compound 3's estimate is 2.3-fold (0.36 log units) above it; low and high end bracket the measured number.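

In this assay, methyl in place of hydrogen on an aromatic carbon, para to a large group, also comes with a lower number: an at least 5.6-fold lower number from compound 2 to compound 3 (0.75 log units; beyond the scatter). Chloro is thus no longer the only group seen to do this at this position, and methyl and chloro cannot be told apart here, with a 1.2-fold higher number from compound 1 to compound 3 (0.08 log units; within the scatter). The step from compound 2 gives only a bound on the size of the change, since compound 2 stands at a limit and not at a number: the limit of > 100000 nM in this assay, at which 1 of the 3 values shown sits.

Going by these compounds, it remains open whether an amine, a carboxylic acid or a longer chain at this position would also come with a lower number. On these data alone, whether chloro or methyl would do the same at another place on this ring also remains open.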